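A few compounds are considered here, and "the series" means these few. Any claim that something is new, unique, unknown or untested is made for them only; others in the source may bear on it.

Measured compounds:
- compound 1, `CC1=NN(C(=O)CCc2ccccc2)C(c2cc(Br)ccc2O)C1`: 17900 nM
- compound 2, `CC1=NN(S(=O)(=O)c2ccc([N+](=O)[O-])cc2)C(c2cc(Br)cc(Br)c2O)C1`: "not active" (no number reported)
- compound 3, `CCNCC(=O)N1N=C(c2cc3ccccc3oc2=O)CC1c1ccccc1`: 30600 nM

In a functional assay on HepG2 cells (Homo sapiens) for cytotoxicity, read by MTT assay, with a stated time of 48 h (on this read-out lower numbers stand for stronger inhibition and higher numbers for weaker inhibition), compound 1 gives 17900 nM. Compound 2 is reported in this assay only as "not active" (no number reported), without a number. Compound 3 gives 30600 nM in this assay; that is the highest of the two numbers, but its gap to compound 1 is within the scatter, so the two cannot be ordered.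

Compound 4, `O=C(CN1CCC(O)CC1)N1N=C(c2cc3ccccc3oc2=O)CC1c1ccccc1`, is not yet measured. It differs from compound 3 in one place:

4-hydroxypiperidin-1-yl in place of ethylamino on a saturated chain carbon bound to a carbonyl carbon

Going by the values given here, no pair of measured compounds differing in one place is available, so the size of this kind of step has no precedent. Among the compounds with values here, both numbers so far sit in the same weak range, and compound 2 gives no number at all. The step from compound 3 to compound 4 is therefore expected to stay within the scatter, with no clear direction, a 1.1-fold higher number from compound 3 to compound 4 (0.06 log units; within the scatter). Compound 4 is estimated at 35000 nM, with a range from 12000 nM to 100000 nM.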

Compound 4, half-maximal inhibitory concentration: "not active" (no number reported)
Nothing numeric was reported for compound 4; no gap can be computed for the estimate.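

No step can be read between compound 3 and compound 4: compound 4 carries no number in this assay, and no evidence at hand bears on this result. Open remains the size of the change from ethylamino to 4-hydroxypiperidin-1-yl, and of any other one-place change in the series.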